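This account rests on a few compounds, and the source may have more. Where it says the series, first, only, none or still open, it means among the compounds named here.

Compound 1, `Cc1cccc(C)c1-c1cc2c(cn1)ncn2-c1ccc(OC(F)F)cc1`, was submitted to an ADME assay on S9 fraction from liver (Mus musculus) for metabolic stability, read by LC-MS, using NADPH, with a stated time of 45 min, tested at 3 uM, in the presence of a further agent that is not named here (a higher number here means that the liver removes a larger share of the compound in one pass, a lower number that the liver removes a smaller share), where compound 1 gives "not determined" (no result reported). For the measured compounds named here, compound 2, `Cc1cc(F)ccc1-c1cc2c(cn1)nc(C)n2-c1ccc(OC(F)F)cc1`, therefore carries the only number in this assay, where compound 2 gives 0.3. Compound 3, `Cc1cc(F)ccc1-c1cc2c(cn1)nc(-c1ccccc1)n2-c1ccc(OC(F)F)cc1`, is reached from compound 2 by a single change: phenyl in place of methyl on an aromatic carbon. Going by the values given here, no step between two measured compounds is available to guide the expectation for phenyl in place of methyl on an aromatic carbon. Compound 3 is expected to give 0.5, between 0.3 and 0.7. That estimate means an expected step of a number 0.20 higher from compound 2 to compound 3 (beyond the scatter), a rise somewhat beyond the usual scatter.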

Compound 3, hepatic extraction ratio in the Mus musculus assay: 0.1
The estimate for compound 3 lay 0.40 above the measured number, and the stated range ends above it.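

On this aromatic carbon, between two ring nitrogen atoms, the first step available for the position shows that phenyl in place of methyl gives, in the Mus musculus assay, a number 0.20 lower from compound 2 to compound 3 (beyond the scatter). In a physicochemical assay for solubility (a higher number here means a more soluble compound, a lower number a less soluble compound), compound 2 gives 71000 nM and compound 3 gives 6000 nM, so the lower number in the Mus musculus assay comes with a loss of solubility: the measured solubility of compound 2, 71000 nM, and of compound 3, 6000 nM, a 12-fold lower number (1.07 log units; beyond the scatter)

This reading rests on a single pair. Going by these compounds, whether an amine or a carboxylic acid on this carbon would keep the lower number in the Mus musculus assay while holding up the number in the physicochemical assay stays open.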